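The source may report more compounds than this note shows. Statements on the series, on what has been measured and on what is new or still open speak of the compounds shown alone.

Measured compounds:
compound 1, `Cc1ccc(N2CCN(Cn3nc(-c4ccc5c(c4)OCCO5)oc3=S)CC2)c(C)c1`: > 50000 nM
compound 2, `S=c1oc(-c2ccc3c(c2)OCCO3)nn1CN1CCN(c2ccc(Cl)cc2)CC1`: > 50000 nM
compound 3, `Fc1ccc(N2CCN(Cn3nc(-c4ccc5c(c4)OCCO5)oc3=S)CC2)cc1`: > 50000 nM

In a functional assay on HeLa cells (Homo sapiens) for antiproliferative activity, read by MTT assay, with a stated time of 48 h (on this read-out lower numbers stand for stronger inhibition and higher numbers for weaker inhibition), compound 1 gives > 50000 nM, which is a limit of the assay and not a number. Compound 2 likewise gives only a limit, > 50000 nM. Compound 3 also gives only a limit, > 50000 nM. Compound 3 therefore stands where every value of the series stands, namely at the limit of > 50000 nM in this assay, at which 3 of the 3 values shown sit. The steps between the three cannot be read: a step that the two limits leave unreadable from compound 1 to compound 2, a step that the two limits leave unreadable from compound 1 to compound 3, a step that the two limits leave unreadable from compound 2 to compound 3.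

Compound 4, `COc1cccc(N2CCN(Cn3nc(-c4ccc5c(c4)OCCO5)oc3=S)CC2)c1`, differs from compound 3 by 3-methoxyphenyl in place of 4-fluorophenyl on an amine nitrogen in a ring. All three measured steps change the same aryl group on the ring nitrogen, and none of them is readable, so no direction for the present change can be drawn from them. No step beyond the scatter is expected from compound 3 to compound 4 in this assay, and a further limit is the most likely outcome. Compound 4 is expected at 80000 nM, with a range of 30000 nM to 300000 nM. The expected step is a step that the limit leaves unreadable from compound 3 to compound 4.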

Compound 4, half-maximal inhibitory concentration: 18000 nM
The estimate for compound 4 lay 4.4-fold (0.65 log units) above the measured number; measured number below the stated range.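

In this assay, the aryl group on the ring nitrogen now gives readable steps, with an at least 2.7-fold lower number from compound 3 to compound 4 (0.44 log units; beyond the scatter) and an at least 2.7-fold lower number from compound 2 to compound 4 (0.44 log units; beyond the scatter) and also an at least 2.7-fold lower number from compound 1 to compound 4 (0.44 log units; beyond the scatter) for the same position. The steps among compounds 1, 2 and 3 cannot be read, and their values are limits of the assay, not numbers: the limit of > 50000 nM in this assay, at which 3 of the 4 values shown sit. Activity in this assay is therefore not fixed by the shared core alone, and 3-methoxyphenyl is the only aryl group shown that brings a value inside the measured range, while its one hydrogen-bond acceptor and its ring position change together.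

The compounds shown do not separate the methoxy group itself from where it stands on the phenyl ring. As far as these compounds go, whether a hydroxyl or an ethoxy group would carry the activity further also remains open.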